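Acetyl for trifluoromethyl: expectation for compound 4

This account rests on a few compounds, and the source may have more. Where it says the series, first, only, none or still open, it means among the compounds named here.

Values in a functional assay on HeLa cells (Homo sapiens) for inhibition, read by CCK-8 assay, with a stated time of 48 h (a higher number here means a weaker inhibitor, a lower number a stronger inhibitor), are these:
- compound 1 `COc1cc(-c2ccnc3cc(-c4ccc(Cl)cc4)nn23)cc(OC)c1OC` gives 1490 nM
- compound 2 `COc1cc(-c2ccnc3cc(-c4ccc5c(ccn5C)c4)nn23)cc(OC)c1OC` gives 19 nM
- compound 3 `COc1cc(-c2ccnc3cc(-c4ccc(C(F)(F)F)cc4)nn23)cc(OC)c1OC` gives 1840 nM

Compound 3 gives 1840 nM in the same range as its nearest neighbour (a 1.2-fold higher number from compound 1 to compound 3 (0.09 log units; within the scatter)) and lies far from the remaining one (a 97-fold higher number from compound 2 to compound 3 (1.99 log units; beyond the scatter)) on the numbers shown. Compound 4 `COc1cc(-c2ccnc3cc(-c4ccc(C(C)=O)cc4)nn23)cc(OC)c1OC` carries acetyl in place of trifluoromethyl on an aromatic carbon, para to a large group (acetyl in place of trifluoromethyl on an aromatic carbon). Among the compounds with values here, the closest precedent is the exchange of one small group at this place (a 1.2-fold higher number from compound 1 to compound 3 (0.09 log units; within the scatter)), which stayed within the scatter. The large steps (a 78-fold lower number from compound 1 to compound 2 (1.89 log units; beyond the scatter) and a 97-fold higher number from compound 2 to compound 3 (1.99 log units; beyond the scatter)) involve 1-methyl-1H-indol-5-yl, which compound 4 does not contain, so they bear on it only weakly. Within the data shown here, no acetyl example has been measured, and a single small exchange is thin evidence. In this assay no step beyond the scatter is expected, and no direction can be assigned. The step expected is a 1.2-fold lower number from compound 3 to compound 4 (0.06 log units; within the scatter) for this estimate. Compound 4 is estimated at 1600 nM with an expected range from 550 nM to 4500 nM for the measurement.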

Compound 4, half-maximal inhibitory concentration: 1810 nM
Compound 4: the middle estimate sits 1.1-fold (0.05 log units) below what was measured, and the stated range covers the measured number.
By their numbers in this assay, from the lowest: compound 2; then compounds 1, 4 and 3 (each within the scatter of the next).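

In this assay, the exchange of trifluoromethyl for acetyl, which adds a hydrogen-bond acceptor and a double bond outside aromatic rings, gives a 1.0-fold lower number from compound 3 to compound 4 (0.01 log units; within the scatter), and the exchange of chloro for acetyl gives a 1.2-fold higher number from compound 1 to compound 4 (0.08 log units; within the scatter), so three different small groups at this place now stand unseparated. The 4-acetylphenyl group stays as far from 1-methyl-1H-indol-5-yl as the other two phenyl groups, with a 95-fold higher number from compound 2 to compound 4 (1.98 log units; beyond the scatter), so among these four compounds only the change to 1-methyl-1H-indol-5-yl gives a step beyond the scatter. Nothing available accounts for this lack of response at this place.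

Going by these compounds, whether an amine or a carboxylic acid at this place would also stay within the scatter remains open. So does which part of 1-methyl-1H-indol-5-yl carries the gap, the methyl on nitrogen or the fused ring, which a 1H-indol-5-yl group without that methyl would begin to separate.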